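Swapping Methyl for Phenyl on a Fused Imide Nitrogen

This account rests on a few compounds, and the source may have more. Where it says the series, first, only, none or still open, it means among the compounds named here.

Compound 1 `COc1cc2c(c(Oc3cccc(NS(=O)(=O)c4ccc(Cl)cc4)c3)n1)C(=O)N(C1CC1)C2=O`: 97%
Compound 2 `Cc1cc2c(c(Oc3cccc(NS(=O)(=O)c4ccc(Cl)cc4)c3)n1)C(=O)N(C)C2=O`: 122%

Both compounds were tested in a functional assay on HEK293 cells for agonist activity at Glucose-dependent insulinotropic receptor (Homo sapiens), read by cAMP accumulation, with a stated time of 30 min; on this read-out higher numbers stand for larger maximal responses and lower numbers for smaller maximal responses. Compound 2 reaches the higher of the two maximal responses, and its gap to compound 1 is wider than the usual scatter. Compound 3 `Cc1cc2c(c(Oc3cccc(NS(=O)(=O)c4ccc(Cl)cc4)c3)n1)C(=O)N(c1ccccc1)C2=O` has not yet been measured. It differs from compound 2 in one place: phenyl in place of methyl on an amide-type nitrogen in a ring. For the measured compounds named here, no measured pair shows this change, so the direction is uncertain. A modest decrease in maximal response is expected, a step of a number 17 percentage points lower from compound 2 to compound 3 (beyond the scatter). Compound 3 is expected to give about 105% in this assay, likely between 70% and 130%.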

Compound 3, largest response reached (reported as efficacy), in percent of the reference or control that the assay uses: 102%
Estimate against measurement, compound 3: 3 percentage points above, and the stated range covers the measured number.
By their numbers in this assay, from the lowest: compounds 1 and 3 (each within the scatter of the next); then compound 2.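

On the amide-type nitrogen in a ring, phenyl in place of methyl gives a number 20 percentage points lower from compound 2 to compound 3 (beyond the scatter) in this assay. For the compounds shown here, this is the first direct reading of a change at this position, and it shows that the much larger phenyl lowers the maximal response without abolishing it, as compound 3 still gives 102% here. Nothing available explains the drop. Going by these compounds, whether ethyl, a longer chain or a benzyl group on this nitrogen would keep the response of compound 2 remains open. A single step gives the direction for this pair only.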